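Exchanging sulfur for oxygen in compound 3

A few compounds are considered here, and "the series" means these few. Any claim that something is new, unique, unknown or untested is made for them only; others in the source may bear on it.

In a functional assay on GOTO cells (Homo sapiens) for cytotoxicity, read by MTT assay, with a stated time of 3 days (a higher number here means a weaker inhibitor, a lower number a stronger inhibitor), compound 1 `N#Cc1c(Nc2ccccc2)nc(SCc2nc3ccccc3[nH]2)nc1-c1ccccc1` gives 6.41 nM, compound 2 `CCNc1nc(SCc2nc3ccccc3[nH]2)nc(-c2ccccc2)c1C#N` gives 3.96 nM and compound 3 `N#Cc1c(NC(N)=S)nc(SCc2nc3ccccc3[nH]2)nc1-c1ccccc1` gives 4.8 nM. Compound 3 cannot be separated from the other two: a 1.3-fold lower number from compound 1 to compound 3 (0.13 log units; within the scatter) and a 1.2-fold higher number from compound 2 to compound 3 (0.08 log units; within the scatter) both lie within the scatter of repeated measurements.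

Compound 4 `N#Cc1c(NC(N)=O)nc(SCc2nc3ccccc3[nH]2)nc1-c1ccccc1` differs from compound 3 by a single exchange, (a group of 3 heavy atoms (1 carbon, 1 nitrogen, 1 oxygen; no ring) in place of a group of 3 heavy atoms (1 carbon, 1 nitrogen, 1 sulfur; no ring), on a nitrogen on an aromatic ring). In plain terms, oxygen takes the place of sulfur in the group on that nitrogen. The group at this place also varies among the three measured compounds, and a 1.6-fold lower number from compound 1 to compound 2 (0.21 log units; within the scatter) stays within the scatter as well. Across these three compounds, then, changing this group has produced no step beyond the scatter. None of them tests the exchange of sulfur for oxygen directly, so the expectation rests on thin evidence. No real change is expected here, and the estimated step is a 1.0-fold higher number from compound 3 to compound 4 (0.02 log units; within the scatter). For compound 4, the expected value is 5 nM, within an estimated range of 2.2 nM to 12 nM.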

Compound 4, half-maximal inhibitory concentration: 11.3 nM
Compound 4: middle estimate off by 2.3-fold (0.35 log units), on the low side; measured number inside the range.
By their numbers in this assay, from the lowest: compounds 2, 3, 1 and 4 (each within the scatter of the next, the first and the last beyond it).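

In this assay, among the compounds shown here, this nitrogen substituent now gives steps beyond the scatter, which none of the earlier compounds did: exchanging sulfur for oxygen gives a modest loss (a 2.4-fold higher number from compound 3 to compound 4 (0.37 log units; beyond the scatter)), even though the counts of heavy atoms, double bonds, hydrogen-bond donors and acceptors stay the same. Carbamoyl is also separated from ethyl (a 2.9-fold higher number from compound 2 to compound 4 (0.46 log units; beyond the scatter)), but not from phenyl (a 1.8-fold higher number from compound 1 to compound 4 (0.25 log units; within the scatter)), so the position responds only modestly and not to every exchange. Nothing available here accounts for the difference between sulfur and oxygen.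

As far as these compounds go, the exchange rests on a single pair, so it remains open whether it would give a similar step with another group on this nitrogen or on another core. From the compounds shown here alone, it is also open how a plain amine, an acetyl group or a longer chain such as butyl would compare at this position.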